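A few compounds are considered here, and "the series" means these few. Any claim that something is new, unique, unknown or untested is made for them only; others in the source may bear on it.

Measured compounds:
- compound 1 `COc1ccc(CNc2nc(C#N)cnc2C(N)=O)cc1` — in an ADME assay on HepG2 cells (Homo sapiens) for cytotoxicity (a higher number here means a weaker inhibitor, a lower number a stronger inhibitor), compound 1 gives "not determined" (no result reported)
- compound 2 `N#Cc1cnc(C(N)=O)c(NCc2ccc(N)cc2)n1` — in this assay compound 2 gives > 1000000 nM

Compound 1 carries a methoxy on its benzyl ring and a carbamoyl on the shared core. Compound 2 carries an amino in place of the methoxy and keeps the carbamoyl. In this assay compound 1 has no number of its own. The value of compound 2 is a limit of the assay, not a measured number (the limit of > 1000000 nM in this assay, at which 1 of the 2 values shown sits), so compound 1 cannot be placed above or below any firm figure; the only measured material around it is that limit.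

Compound 3 `COc1ccc(CNc2nc(C#N)cnc2C#N)cc1` differs from compound 1 by cyano in place of carbamoyl on an aromatic carbon, in words cyano in place of carbamoyl on an aromatic carbon. Within the data shown here, no measured step covers this change, so no size or direction for it can be read from the data. Compound 3 is expected to give about 1000000 nM, within a range of 100000 nM to 3000000 nM.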

Compound 3, half-maximal inhibitory concentration: 95900 nM
Beside the measured number, compound 3's estimate is 10-fold (1.02 log units) above it; the whole stated range lies above it.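

No step can be read from this result: in this assay compound 3 gives 95900 nM, but compound 1, which differs from it in one place, has no number to set against it. The compounds shown leave open how cyano in place of carbamoyl changes the value.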